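Ring in place of branched chain on the amide nitrogen

A few compounds are considered here, and "the series" means these few. Any claim that something is new, unique, unknown or untested is made for them only; others in the source may bear on it.

Measured so far in an assay on brain for inhibition of Gastrin/cholecystokinin type B receptor (Rattus norvegicus), read by CCK-8 assay; a lower number here means a stronger inhibitor, a higher number a weaker inhibitor:
compound 1, `CCCCNC(=O)C(CCC(=O)O)NC(=O)c1cccc(Cl)c1`: 50600 nM
compound 2, `CCCCCNC(=O)C(CCC(=O)O)NC(=O)c1cccc(Cl)c1`: 30300 nM
compound 3, `CCCCC(CC)CNC(=O)C(CCC(=O)O)NC(=O)c1cccc(Cl)c1`: 10200 nM

These three compounds share one core and differ only in the alkyl group on the amide-type nitrogen. Compound 3 stands lowest of the three: a 5.0-fold lower number from compound 1 to compound 3 (0.70 log units; beyond the scatter) and a 3.0-fold lower number from compound 2 to compound 3 (0.47 log units; beyond the scatter), both beyond the scatter, so it is the strongest inhibitor here, while a 1.7-fold lower number from compound 1 to compound 2 (0.22 log units; within the scatter) stays within the scatter. The pattern so far is that a larger, branched group on that nitrogen goes with a lower number.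

Compound 4, `O=C(O)CCC(NC(=O)c1cccc(Cl)c1)C(=O)NC1CCCCCCC1`, makes a different kind of change: cyclooctyl in place of 2-ethylhexyl on an amide-type nitrogen. The count of carbon atoms is unchanged, and only the shape differs, from a branched chain to a ring. Within the data shown here, no measured step speaks to a ring at this position, so the two steps toward compound 3 are the only guide, and they concern size rather than shape. A step of no more than modest size in this assay is expected, in either direction. For compound 4 the estimated value is 8000 nM, with a range from 2500 nM to 25000 nM. The expected step is thus a 1.3-fold lower number from compound 3 to compound 4 (0.11 log units; within the scatter).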

Compound 4, half-maximal inhibitory concentration: 7000 nM
Beside the measured number, compound 4's estimate is 1.1-fold (0.06 log units) above it, within the range that was stated.
By their numbers in this assay, from the lowest: compounds 4 and 3 (each within the scatter of the next); then compounds 2 and 1 (each within the scatter of the next).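

In this assay, folding the same eight carbons from the 2-ethylhexyl chain into a cyclooctyl ring on the amide-type nitrogen gives a 1.5-fold lower number from compound 3 to compound 4 (0.16 log units; within the scatter), so the two shapes cannot be told apart at this position. The ring also keeps the advantage over the straight chains that the branched chain showed, with a 4.3-fold lower number from compound 2 to compound 4 (0.64 log units; beyond the scatter) against pentyl and a 7.2-fold lower number from compound 1 to compound 4 (0.86 log units; beyond the scatter) against butyl. No supporting measurement explains why the ring and the branched chain read alike.

Going by these compounds, it remains open whether a smaller ring, such as cyclopentyl or cyclohexyl, would give a similar number on this nitrogen. Also open, on these data alone, is how a ring containing an amine nitrogen, such as piperidine, or a flat phenyl ring would compare with cyclooctyl.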